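This account rests on a few compounds, and the source may have more. Where it says the series, first, only, none or still open, it means among the compounds named here.

Compound 1 `Cc1ccc(S(=O)(=O)n2cc(-c3cc(C(F)(F)F)cc(-c4cn(S(=O)(=O)c5ccc(C)cc5)c5cc(Br)ccc45)n3)c3ccc(Br)cc32)cc1`: in a functional assay on P388 cells (Mus musculus) for cytotoxicity (on this read-out lower numbers stand for stronger inhibition and higher numbers for weaker inhibition), compound 1 gives only a limit, > 100000 nM.
Compound 2 `Cc1ccc(S(=O)(=O)n2cc(-c3cc(C(F)(F)F)ccn3)c3cc(OCc4ccccc4)ccc32)cc1`: in this assay compound 2 gives only a limit, > 100000 nM.
Compound 3 `COc1ccc2c(c1)c(-c1cc(C(F)(F)F)c(C#N)c(-c3cn(S(=O)(=O)c4ccc(C)cc4)c4ccc(OC)cc34)n1)cn2S(=O)(=O)c1ccc(C)cc1`: in this assay compound 3 gives only a limit, > 100000 nM.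

All three values sit at the same limit of the assay, (the limit of > 100000 nM in this assay, at which 3 of the 3 values shown sit), so no number is known for any of them, and compound 3 cannot be placed above or below the other two. Compound 4 `COc1ccc2c(c1)c(-c1cc(C(F)(F)F)cc(-c3cn(S(=O)(=O)c4ccc(C)cc4)c4ccc(OC)cc34)n1)cn2S(=O)(=O)c1ccc(C)cc1` has not yet been measured. It differs from compound 3 in one place: hydrogen in place of cyano on an aromatic carbon. Among the compounds with values here, no step between two measured compounds is available to show what such a change does here. The expected change in this assay is a number no higher from compound 3 to compound 4 (the limit leaves the size open), none beyond the scatter. Compound 4 is therefore estimated at 100000 nM, with a range from 30000 nM to 300000 nM, most likely reported again only as a limit.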

Compound 4, half-maximal inhibitory concentration: > 100000 nM
Compound 4: a limit, no number (the forecaster's own chance of this, stated with the estimate: 85%); the middle value sits exactly at the limit.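

Compound 3 and compound 4 both give only a limit, so swapping cyano for hydrogen yields no readable step: the limit of > 100000 nM in this assay, at which 4 of the 4 values shown sit. The compounds shown leave open what cyano changes in this assay and how the four compounds rank among themselves.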